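From sec-Butyl to Isopentyl on an Aromatic Nitrogen

This account rests on a few compounds, and the source may have more. Where it says the series, first, only, none or still open, it means among the compounds named here.

In a functional assay on LNCaP cells (Homo sapiens) for inhibition, read by WST assay, with a stated time of 3 days (a lower number here means a stronger inhibitor, a higher number a weaker inhibitor), compound 1 (`CCCn1ccnc1/C=C/C(=O)/C=C/c1coc2ccccc2c1=O`) gives 2100 nM and compound 2 (`CCC(C)n1ccnc1/C=C/C(=O)/C=C/c1coc2ccccc2c1=O`) gives 1300 nM. Of the two measured compounds, compound 2 has the lower number, but its value lies within the scatter of the value for compound 1, so no real order can be read between them.

Compound 3 (`CC(C)CCn1ccnc1/C=C/C(=O)/C=C/c1coc2ccccc2c1=O`) keeps the shared core and carries isopentyl in place of sec-butyl on an aromatic nitrogen. Among the compounds with values here, only one measured step bears on this change, as it also alters the group on that nitrogen, and it is a 1.6-fold lower number from compound 1 to compound 2 (0.21 log units; within the scatter). Within the data shown here, that step is a methyl in place of hydrogen on a saturated chain carbon, and no measured compound carries isopentyl. Two compounds show no trend with the group on the nitrogen. Among the measured compounds shown here, with that single step within the scatter as the only guide, no step beyond the scatter is expected in this assay, and no direction is favoured. The estimate amounts to an expected 1.2-fold higher number from compound 2 to compound 3 (0.06 log units; within the scatter). For compound 3, the expected value is 1500 nM, with an estimated range from 700 nM to 3200 nM.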

Compound 3, half-maximal inhibitory concentration: 4000 nM
For compound 3 the middle estimate is 2.7-fold (0.43 log units) below the measured one; the measured number lies above the stated range.
By their numbers in this assay, from the lowest: compounds 2, 1 and 3 (each within the scatter of the next, the first and the last beyond it).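

In this assay, within the data shown here, the change from sec-butyl to isopentyl gives a 3.1-fold higher number from compound 2 to compound 3 (0.49 log units; beyond the scatter) and is the first step at this position to lie beyond the scatter, though only a modest one. The group on the aromatic nitrogen therefore does matter to some degree in these cells, which the earlier pair alone could not show. Measured against the group of the other earlier compound, isopentyl gives a 1.9-fold higher number from compound 1 to compound 3 (0.28 log units; within the scatter) and stays within the scatter, so the one clear difference lies between sec-butyl and isopentyl, and no steady trend with the group on this nitrogen can be drawn from three compounds.

As far as these compounds go, whether a different kind of group on this nitrogen, such as a longer chain ending in an amine or a carboxylic acid, would move the number in either direction remains open. Nothing available accounts for the difference between sec-butyl and isopentyl at this position.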